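This account rests on a few compounds, and the source may have more. Where it says the series, first, only, none or still open, it means among the compounds named here.

Compound 1: `CC1(C)Oc2ccc(C#N)cc2[C@@H](/N=C(\NC#N)Nc2cccc([N+](=O)[O-])c2)[C@@H]1O` — 670 nM
Compound 2: `CC1(C)Oc2ccc(C#N)cc2[C@@H](/N=C(\NC#N)Nc2cccc(C(=O)O)c2)[C@@H]1O` — > 100000 nM
Compound 3: `CC1(C)Oc2ccc(C#N)cc2[C@@H](/N=C(\NC#N)Nc2ccc3c(c2)CCC3)[C@@H]1O` — not yet measured

In a functional assay (aorta) with Rattus norvegicus as the target (a higher number here means a weaker inhibitor, a lower number a stronger inhibitor), compound 1 gives 670 nM. For compound 2 the assay reports only a limit, > 100000 nM, so compound 2 stands at the limit of > 100000 nM in this assay, at which 1 of the 2 values shown sits. Among the measured compounds shown here, the single measured step is an at least 140-fold higher number from compound 1 to compound 2 (2.17 log units; beyond the scatter), carboxy in place of nitro on an aromatic carbon.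

Compound 3 differs from compound 2 by 2,3-dihydro-1H-inden-5-yl in place of 3-carboxyphenyl on an amine nitrogen. For the measured compounds named here, the only step that bears on this change is the one that brought the carboxy group in, and it was large; compound 3 removes that group again, so a large step back toward stronger inhibition is expected, with the estimated step being an at least 100-fold lower number from compound 2 to compound 3 (2.00 log units; beyond the scatter). Going by the values given here, no measured pair shows what the 2,3-dihydro-1H-inden-5-yl group itself does, so the range is kept wide. Compound 3 is expected to give about 1000 nM in this assay, between 150 nM and 15000 nM.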

Compound 3, half-maximal inhibitory concentration: 41300 nM
Estimate against measurement, compound 3: 41-fold (1.62 log units) below; measured number outside the range, above it.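

In this assay the change brings an at least 2.4-fold lower number from compound 2 to compound 3 (0.38 log units; beyond the scatter), a step known only as a bound, since compound 2 stands at a limit: the limit of > 100000 nM in this assay, at which 1 of the 3 values shown sits.

Removing the carboxy group therefore does not by itself recover the level of compound 1, as the comparison with the 3-nitrophenyl compound gives a 62-fold higher number from compound 1 to compound 3 (1.79 log units; beyond the scatter). On this amine nitrogen, both replacements of 3-nitrophenyl shown give a weaker inhibitor than compound 1, one carrying a carboxy group and one a 2,3-dihydro-1H-inden-5-yl group with no such group.

As far as these compounds go, what remains open is whether the nitro group itself matters or whether a chloro group, a nitrile or an amine in its place on the phenyl ring would stay near compound 1. The compounds shown also do not separate the effect of the fused five-membered ring from that of losing the nitro group.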